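Dropping the Nitro Group from Compound 1

The source may report more compounds than this note shows. Statements on the series, on what has been measured and on what is new or still open speak of the compounds shown alone.

In a physicochemical assay, read by spectrophotometry, with a stated time of 30 min (a higher number here means a weaker inhibitor, a lower number a stronger inhibitor), compound 1 (`O=C(CCc1nc2ccccc2c(=O)[nH]1)N/N=C/c1ccc([N+](=O)[O-])cc1`) gives 328000000 nM as its reading. Compound 3 (`O=C(CCCc1nc2ccccc2c(=O)[nH]1)N/N=C/c1ccc([N+](=O)[O-])cc1`), which also carries the 4-nitrophenyl group, gives 316000000 nM and so lies within the scatter of compound 1. Compound 2 (`O=C(CCCc1nc2ccccc2c(=O)[nH]1)N/N=C/c1cc(O)c(O)c(O)c1`) gives 78000000 nM as the lowest number of the three, beyond the scatter of compound 1.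

Compound 4 (`O=C(CCc1nc2ccccc2c(=O)[nH]1)N/N=C/c1ccccc1`) has hydrogen in place of nitro on an aromatic carbon and is otherwise the same as compound 1. Among the compounds with values here, only one measured step touches this aromatic group: swapping 3,4,5-trihydroxyphenyl for 4-nitrophenyl gives a 4.1-fold higher number from compound 2 to compound 3 (0.61 log units; beyond the scatter) and that step is modest. Within the data shown here, no measured compound has a plain phenyl group, so that step limits the likely size but does not settle the direction. A small move towards a lower number, within the scatter, is expected. The estimated change is a 1.3-fold lower number from compound 1 to compound 4 (0.12 log units; within the scatter) with either direction still possible. For compound 4 the expected value is 250000000 nM with an estimated range from 100000000 nM to 500000000 nM in this test.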

Compound 4, half-maximal inhibitory concentration: 734000000 nM
Compound 4: the middle estimate sits 2.9-fold (0.47 log units) below what was measured; the whole stated range lies below it.
By their numbers in this assay, from the lowest: compound 2; then compounds 3 and 1 (each within the scatter of the next); then compound 4.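

Taking the nitro group away altogether gives a 2.2-fold higher number from compound 1 to compound 4 (0.35 log units; beyond the scatter) in this assay, so the bare aromatic ring does not match the 4-nitrophenyl group here. The earlier step only exchanged one substituted ring for another, whereas this one compares a group with a plain hydrogen on the same aromatic carbon and settles the direction for this pair: the phenyl compound has the higher number, meaning the weaker inhibitor. No measurement shown explains why removing the nitro group has this effect.

On these data alone, it remains open whether an amine or a carboxylic acid on that aromatic carbon would lower the number or raise it. Also open, as far as these compounds go, is whether replacing nitro with hydrogen on compound 3, which has the longer chain, would produce a step of similar size.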